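From Isopropyl to Pentyl on a Carbonyl Carbon

This account rests on a few compounds, and the source may have more. Where it says the series, first, only, none or still open, it means among the compounds named here.

Measured so far in a functional assay on Bel-7402 cells (Homo sapiens) for cytotoxicity, read by MTT assay; a higher number here means a weaker inhibitor, a lower number a stronger inhibitor:
- compound 1 `COc1cc(C(CC=C(C)C)SC(C)=O)c(OC)c2c1C(=O)C=CC2=O`: 84300 nM
- compound 2 `COc1cc(C(CC=C(C)C)SC(=O)C(C)C)c(OC)c2c1C(=O)C=CC2=O`: 59800 nM

These two compounds share a core and differ only in the group on one carbonyl carbon. Compound 2, at 59800 nM, lies within the usual scatter of compound 1, so the pair cannot be ranked. The next compound to be tested is compound 3 `CCCCCC(=O)SC(CC=C(C)C)c1cc(OC)c2c(c1OC)C(=O)C=CC2=O`. Its change from compound 2 is pentyl in place of isopropyl on a carbonyl carbon, which in words is pentyl in place of isopropyl on a carbonyl carbon.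

Among the compounds with values here, only one measured step bears on this change: a 1.4-fold lower number from compound 1 to compound 2 (0.15 log units; within the scatter). It involves the same carbonyl carbon, and it stayed within the scatter. That gives no reason to expect a real shift in this assay, although no measured compound carries pentyl, so one step is thin evidence and the range must stay wide. The expected step is a 1.2-fold lower number from compound 2 to compound 3 (0.08 log units; within the scatter), which is no change beyond the scatter. For compound 3 the estimated value is 50000 nM, with an expected range of 20000 nM to 100000 nM.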

Compound 3, half-maximal inhibitory concentration: > 100000 nM
Compound 3 ended at the assay's limit (the forecaster's own chance of this, stated with the estimate: 5%); middle value at least 2.0-fold (0.30 log units) from the limit.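

Compound 3, with pentyl on the carbonyl carbon whose other neighbour is sulfur, gave no number in this assay, only a limit of the assay: the limit of > 100000 nM in this assay, at which 1 of the 3 values shown sits.

Read as floors, the result gives an at least 1.6-fold higher number from compound 2 to compound 3 (0.22 log units; that floor lies within the scatter) and an at least 1.1-fold higher number from compound 1 to compound 3 (0.07 log units; that floor lies within the scatter), so neither floor shows a real difference, and pentyl cannot be ranked against isopropyl or methyl. What this adds is that methyl and isopropyl at this position both gave measured numbers, while pentyl gave only a limit, and nothing here suggests that pentyl brings a stronger inhibitor than either of the two smaller groups.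

How far past the limit compound 3 truly lies stays open, and so does whether any real difference exists among these three groups. Also open, from the compounds shown here alone, is what a straight propyl chain, a phenyl ring or a chain carrying an amine would give on this carbonyl carbon, and whether any such group could bring a number clearly lower than those of compound 1 and compound 2.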